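Replacing the Nitro Group of Compound 3 with Amino

The compounds below may be only part of what the source reports. "The series", "measured", "known", "first", "only" and "open" are said of these compounds alone.

Measured in a functional assay on KB cells (Homo sapiens) for antiproliferative activity, read by colorimetric assay and MTT assay; on this read-out higher numbers stand for weaker inhibition and lower numbers for stronger inhibition:
- compound 1 `COc1ccc(S(=O)(=O)Nc2cccc3cc[nH]c23)cc1`: 0.67 ug/mL
- compound 2 `O=S(=O)(Nc1cccc2cc[nH]c12)c1ccc(Cl)cc1`: 6 ug/mL
- compound 3 `O=[N+]([O-])c1ccc(S(=O)(=O)Nc2cccc3cc[nH]c23)cc1`: 15 ug/mL

Compound 3 has the highest number of the three, making it the weakest inhibitor here. Compound 4 `Nc1ccc(S(=O)(=O)Nc2cccc3cc[nH]c23)cc1` keeps the shared core but has amino in place of nitro on an aromatic carbon, para to a large group: amino in place of nitro on an aromatic carbon. Two measured steps end in this nitro group: the large 22-fold higher number from compound 1 to compound 3 (1.35 log units; beyond the scatter) and the modest 2.5-fold higher number from compound 2 to compound 3 (0.40 log units; beyond the scatter). Going by the values given here, neither measured replacement for nitro gives a higher number, but no amino compound has been measured, so this guide is limited. A modest to large drop is expected, with an estimated 5.0-fold lower number from compound 3 to compound 4 (0.70 log units; beyond the scatter). For compound 4, the estimated value is 3 ug/mL, with an expected range of 0.7 ug/mL to 12 ug/mL.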

Compound 4, half-maximal inhibitory concentration: 36 ug/mL
The estimate for compound 4 lay 12-fold (1.08 log units) below the measured number; the whole stated range lies below it.
By their numbers in this assay, from the lowest: compound 1; then compound 2; then compound 3; then compound 4.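

In this assay, amino ranks as the weakest of the four groups at this place on the ring, and swapping out nitro brings no gain, with a 2.4-fold higher number from compound 3 to compound 4 (0.38 log units; beyond the scatter). The other comparisons give a 6.0-fold higher number from compound 2 to compound 4 (0.78 log units; beyond the scatter) and a 54-fold higher number from compound 1 to compound 4 (1.73 log units; beyond the scatter), so this single position spans a wider range than the first three compounds showed, with methoxy still the strongest. No measurement shown here explains this order. On these data alone, how an ethoxy group, a dimethylamino group or a carboxylic acid would rank at this place remains open.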